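Cyclohexyl for phenyl on the imine nitrogen: compound 4

A few compounds are considered here, and "the series" means these few. Any claim that something is new, unique, unknown or untested is made for them only; others in the source may bear on it.

Measured so far:
- compound 1 `CC1CC(=O)c2s/c(=N/c3ccccc3)oc2C1`: 2720 nM
- compound 2 `CC(C)C1CC(=O)c2s/c(=N/c3ccccc3)oc2C1`: 2280 nM
- compound 3 `CC1(C)CC(=O)c2s/c(=N/C3CCCCC3)oc2C1`: 12500 nM

In a functional assay on NCI-H23 cells (Homo sapiens) for antiproliferative activity, read by sulforhodamine B assay (a lower number here means a stronger inhibitor of growth, a higher number a weaker inhibitor of growth), compound 2 gives the lowest of the three numbers, yet compound 1 lies within the scatter of it, so the two cannot be ordered; compound 3 gives a number clearly above both. For the measured compounds named here, the one measured step, a 1.2-fold lower number from compound 1 to compound 2 (0.08 log units; within the scatter), changes only the group on the saturated ring carbon and leaves the assay readout essentially where it was.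

Compound 4 `CC(C)C1CC(=O)c2s/c(=N/C3CCCCC3)oc2C1` is not yet measured. Against compound 2 the change is cyclohexyl in place of phenyl on a double-bonded nitrogen. Going by the values given here, no measured pair isolates this change: compound 3 also carries cyclohexyl on the double-bonded nitrogen, but its saturated ring differs from both compound 1 and compound 2, so its higher number cannot be attributed to one position alone. The numbers shown nonetheless point toward a higher value for cyclohexyl in this assay, and compound 4 is expected to follow that, with a step of a 3.9-fold higher number from compound 2 to compound 4 (0.60 log units; beyond the scatter) beyond the scatter. Compound 4 is therefore estimated at 9000 nM, within the range 3000 nM to 27000 nM.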

Compound 4, concentration for 50% growth inhibition: 7080 nM
Estimate against measurement, compound 4: 1.3-fold (0.10 log units) above; the measured number falls inside the stated range.
By their numbers in this assay, from the lowest: compounds 2 and 1 (each within the scatter of the next); then compounds 4 and 3 (each within the scatter of the next).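

In this assay, the change on the double-bonded nitrogen now has a clean reading, with a 3.1-fold higher number from compound 2 to compound 4 (0.49 log units; beyond the scatter) and the rest of the structure held constant. Within this pair, the phenyl group gives the lower number, and the step lies beyond the scatter. Phenyl and cyclohexyl match in heavy atoms, hydrogen-bond donors, hydrogen-bond acceptors and net charge, so the computed comparison separates them only as an aromatic and a non-aromatic ring, and no available measurement explains the step.

The compounds shown leave open whether this step holds with other groups on the saturated ring carbon, such as the methyl of compound 1. Also open, on these data alone, is how this position responds to other groups on the nitrogen, such as a pyridine ring or a straight butyl chain.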